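Replacing Carboxy with Hydroxymethyl on the Nonyl Compound

A few compounds are considered here, and "the series" means these few. Any claim that something is new, unique, unknown or untested is made for them only; others in the source may bear on it.

In a functional assay on HepG2 cells (Homo sapiens) for cytotoxicity, read by WST assay, with a stated time of 24 h (a higher number here means that more compound is tolerated, a lower number that less compound is tolerated), compound 2 `CCCCCCCCCc1cc(-c2ccc3cc(C(=O)O)ccc3c2)ccc1O` gives 1.73 ug/mL as the lower of two numbers, against compound 1 `CCCC=Cc1cc(-c2ccc3cc(C(=O)O)ccc3c2)ccc1O` with 5.38 ug/mL so far. Compound 3 `CCCCCCCCCc1cc(-c2ccc3cc(CO)ccc3c2)ccc1O` differs from compound 2 by hydroxymethyl in place of carboxy on an aromatic carbon and carries hydroxymethyl in place of carboxy on an aromatic carbon. Among the measured compounds shown here, the only measured step of a 3.1-fold lower number from compound 1 to compound 2 (0.49 log units; beyond the scatter) was modest and concerned a chain, so it says little about this swap. A change no larger is expected in this assay with no direction settled, and the estimated 1.3-fold higher number from compound 2 to compound 3 (0.10 log units; within the scatter) stays small. Compound 3 is estimated at 2.2 ug/mL within a range from 0.8 ug/mL to 7 ug/mL for now.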

Compound 3, concentration lethal to 50% of the cells: 7.25 ug/mL
Estimate against measurement, compound 3: 3.3-fold (0.52 log units) below, and the stated range ends below it.
By their numbers in this assay, from the lowest: compound 2; then compounds 1 and 3 (each within the scatter of the next).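

Hydroxymethyl in place of carboxy gives a 4.2-fold higher number from compound 2 to compound 3 (0.62 log units; beyond the scatter) in this assay, so more compound is tolerated. The earlier step changed only the chain, whereas this one shows that the position on the aromatic carbon also matters, with the nonyl chain held fixed. Nothing available explains the shift.

On these data alone, it remains open whether an amine or a methyl ester at this position would move the number further, and in which direction. As far as these compounds go, it is also open whether the same swap would give a similar step with the pent-1-en-1-yl chain of compound 1.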